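The compounds below may be only part of what the source reports. "The series", "measured", "known", "first", "only" and "open" are said of these compounds alone.

Working notes on the series. Compound 1 `Oc1cccc(-c2cc(-c3ccccc3)nc(-c3ccncc3)c2)c1` gives 0.9% in an assay on isolated protein for inhibition of DNA topoisomerase 1 (Homo sapiens), with a stated time of 30 min, tested at 20 uM (a higher number here means a stronger effect of the compound at the concentration tested, a lower number a weaker effect), a weak effect at the concentration tested. Compound 2 `Oc1ccc(-c2cc(-c3ccccc3)nc(-c3ccco3)c2)cc1` was tested in the same setting but has no number to show: it stands at "not determined" (no result reported), so there is nothing to compare against. Compound 3 `Oc1ccc(-c2cc(-c3ccccc3)nc(-c3ccncc3)c2)cc1` follows from compound 2 by pyridin-4-yl in place of furan-2-yl on an aromatic carbon. Going by the values given here, with no measured pair of this kind, the size of the step in this assay cannot be read from the data; no change beyond the usual scatter is assumed, in either direction. Compound 3 is therefore expected to give about 3% in this assay, estimated between 0% and 15%.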

Compound 3, a percentage reported as inhibition, at one concentration (the size of the read-out at that concentration, not a potency): 5.8%
Compound 3: middle estimate off by 2.8 percentage points, on the low side; the range from low to high includes it.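

With pyridin-4-yl held constant, 4-hydroxyphenyl in place of 3-hydroxyphenyl in this assay gives a number 4.9 percentage points higher from compound 1 to compound 3 (within the scatter), so moving the hydroxyl on this ring does not separate the two compounds. The step from furan-2-yl to pyridin-4-yl cannot be read, as compound 2 has no number. No evidence on the cause of this result is at hand.

Open, as far as these compounds go, is whether any replacement on this ring gives a step beyond the scatter. An amine or a carboxylic acid in place of the hydroxyl would test this.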